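Phenyl for Isopropyl: from Compound 2 to Compound 3

A few compounds are considered here, and "the series" means these few. Any claim that something is new, unique, unknown or untested is made for them only; others in the source may bear on it.

Compound 1 `COC(=O)c1nc(C)n(-c2ccc(C(F)(F)F)cc2)n1` gives 9100 nM in a functional assay on Jurkat cells (Homo sapiens) for inhibition, read by MTT assay, with a stated time of 72 h; on this read-out higher numbers stand for weaker inhibition of growth and lower numbers for stronger inhibition of growth.
Compound 2 `COC(=O)c1nc(C(C)C)n(-c2ccc(F)cc2)n1` gives > 100000 nM in this assay.

For compound 2 this value is only a limit of the assay, not a number: compound 2 sits at the limit of > 100000 nM in this assay, at which 1 of the 2 values shown sits. Compound 3 `COC(=O)c1nc(-c2ccccc2)n(-c2ccc(F)cc2)n1` differs from compound 2 in a single place: phenyl in place of isopropyl on an aromatic carbon. Going by the values given here, no measured pair shows this change, so its direction is open; a move toward stronger inhibition in this assay is expected, though compound 3 may again reach only a limit. Compound 3 is estimated at 60000 nM, between 15000 nM and 200000 nM, an expected step of an at least 1.6-fold lower number from compound 2 to compound 3 (0.22 log units; that floor lies within the scatter).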

Compound 3, concentration for 50% growth inhibition: 10000 nM
For compound 3 the middle estimate is 6.0-fold (0.78 log units) above the measured one, outside the stated range (below it).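

In this assay, phenyl in place of isopropyl on this aromatic carbon gives an at least 10-fold lower number from compound 2 to compound 3 (1.00 log units; beyond the scatter), so the group at this position clearly affects growth inhibition. The step is a floor and not an exact size, as compound 2 has only a limit: the limit of > 100000 nM in this assay, at which 1 of the 3 values shown sits.

The compounds shown leave open whether the aromatic ring itself matters or whether a saturated ring of the same size, cyclohexyl, would serve equally well. Compound 1 differs from compound 3 in more than one place, so it cannot settle this.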